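Methyl-to-hydrogen steps across two cores: working notes

A few compounds are considered here, and "the series" means these few. Any claim that something is new, unique, unknown or untested is made for them only; others in the source may bear on it.

Measured so far in a functional assay on L1210 cells (Mus musculus) for antiproliferative activity; on this read-out higher numbers stand for higher potency (the scale is a negative logarithm) and lower numbers for lower potency:
compound 1 `CN(C)/N=N/c1ccc(C(N)=O)cc1` gives 3.51
compound 2 `CC(C)Cc1nc(/N=N/N(C)C)c(C(N)=O)[nH]1` gives 3.53
compound 3 `CCN(C)/N=N/c1ccc(C(N)=O)cc1` gives 3.66

Compound 3 and compound 1 share a core and differ in one place only, (hydrogen in place of methyl on a saturated chain carbon bound to an amine nitrogen). The step this made in this assay is a number 0.15 log units lower from compound 3 to compound 1 (within the scatter). Compound 2 stands on a different core; how the two cores differ is not broken down here. Its value sits between the other two, and all three numbers lie within the scatter of one another, so no order among them can be read.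

Compound 4 `CCCc1nc(/N=N/N(C)C)c(C(N)=O)[nH]1` is not yet measured. It is reached from compound 2 by hydrogen in place of methyl on a saturated chain carbon bound to two saturated chain carbons. For the measured compounds named here, this is the same kind of change as the one from compound 3 to compound 1: a methyl leaves and a hydrogen enters. The surroundings differ, however. In the measured pair the place is a saturated chain carbon bound to an amine nitrogen; in the new pair it is a saturated chain carbon bound to two saturated chain carbons, and the change sits on the other core.

Given that the one measured instance of this kind of change, a number 0.15 log units lower from compound 3 to compound 1 (within the scatter), stayed within the scatter, the step from compound 2 to compound 4 in this assay is expected to be small as well, about a number 0.08 log units lower from compound 2 to compound 4 (within the scatter). Compound 4 is therefore estimated at 3.45 in this assay, with a range from 3.15 to 3.75; the wider band reflects that the reference step comes from a different core and a different place.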

Compound 4, logarithm of the reciprocal of the active concentration, log(1/C): 3.42
Compound 4: middle estimate off by 0.03 log units, on the high side; measured number inside the range.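

The new step in this assay is a number 0.11 log units lower from compound 2 to compound 4 (within the scatter). Set side by side, the two steps show no difference, so on these two cores the loss of a methyl in favour of hydrogen behaves alike within what this read-out can resolve: the same change on two cores in this assay, a number 0.15 log units lower (within the scatter) from compound 3 to compound 1 and a number 0.11 log units lower (within the scatter) from compound 2 to compound 4, 0.04 log units apart, within the scatter of two such steps. This is agreement of two small steps only, and it does not establish a fixed step size that carries from one core to another, since neither step stands clear of the scatter and one pair per core cannot separate the effect of the core from that of the place, which is a saturated chain carbon bound to an amine nitrogen in one pair and a saturated chain carbon bound to two saturated chain carbons in the other.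

The chains shown on the core of compound 2 are limited to isobutyl and propyl, so it remains open whether a longer chain such as hexyl, or a chain ending in an amine or a carboxylic acid, would give a step beyond the scatter. Also open, on these data alone, is whether the same change made at one identical place on both cores would still give matching steps.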